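The compounds below may be only part of what the source reports. "The series", "measured", "known", "first", "only" and "open" are said of these compounds alone.

Notes on the series in a toxicity assay on MT4 cells (Homo sapiens) for cytotoxicity, read by MTT assay, with a stated time of 5 days; a higher number here means that more compound is tolerated, a lower number that less compound is tolerated: compound 1 `Cc1cnc(Nc2ccc(C#N)cc2)nc1Nc1c(F)cc(-c2ccco2)cc1F`, carrying furan-2-yl, gives 8100 nM. Compound 2 `Cc1cnc(Nc2ccc(C#N)cc2)nc1Nc1c(F)cc(-c2ccnc(F)c2)cc1F` gives 167000 nM, and compound 3 `Cc1cnc(Nc2ccc(C#N)cc2)nc1Nc1c(F)cc(-c2cc(F)nc(F)c2)cc1F` gives 103000 nM. Replacing furan-2-yl accounts for two large steps, a 21-fold higher number from compound 1 to compound 2 (1.31 log units; beyond the scatter) and a 13-fold higher number from compound 1 to compound 3 (1.10 log units; beyond the scatter). Adding fluoro to the pyridine ring gives a 1.6-fold lower number from compound 2 to compound 3 (0.21 log units; within the scatter), so compound 3 stands level with compound 2 and well clear of compound 1.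

Compound 4 `Cc1cnc(Nc2ccc(C#N)cc2)nc1Nc1c(F)cc(-c2ccc(C#N)nc2)cc1F` carries 6-cyanopyridin-3-yl in place of 2,6-difluoropyridin-4-yl on an aromatic carbon. Among the measured compounds shown here, no measured step tests this exchange directly, so the evidence is indirect. Compound 4 keeps a six-membered aromatic ring with one hetero atom, as compound 2 and compound 3 do, which points to a value nearer theirs than that of compound 1. The small fluoro step, a 1.6-fold lower number from compound 2 to compound 3 (0.21 log units; within the scatter), says little about removing both fluoro groups and adding a nitrile. A moderate downward step in this assay is therefore expected, much smaller than the steps away from furan-2-yl, and it may not clear the scatter by much. The estimate means a 2.6-fold lower number from compound 3 to compound 4 (0.41 log units; beyond the scatter), as an expected step. For compound 4 the estimated value is 40000 nM, with an expected range of 10000 nM to 150000 nM.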

Compound 4, half-maximal cytotoxic concentration: 62000 nM
Compound 4: middle estimate off by 1.6-fold (0.19 log units), on the low side; the measured number falls inside the stated range.
By their numbers in this assay, from the lowest: compound 1; then compounds 4, 3 and 2 (each within the scatter of the next, the first and the last beyond it).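

The result adds a third six-membered aromatic ring with one hetero atom at this position, on an aromatic carbon meta to two fluoro groups and para to a large group, and it also stands well clear of furan-2-yl in this assay (a 7.7-fold higher number from compound 1 to compound 4 (0.88 log units; beyond the scatter)). Fluoro on the pyridine ring is thus not required for a number of this order, since 6-cyanopyridin-3-yl carries a nitrile and no fluoro, yet compound 4 cannot be told apart from the difluoro compound (a 1.7-fold lower number from compound 3 to compound 4 (0.22 log units; within the scatter)), while the step from the monofluoro compound clears the scatter (a 2.7-fold lower number from compound 2 to compound 4 (0.43 log units; beyond the scatter)). No measured property of these groups is available to account for any of these steps.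

Because the ring's attachment and its substituent change together in compound 4, the compounds shown do not separate the contribution of the nitrile from that of the way the pyridine ring is attached. On these data alone, it also stays open whether an unsubstituted phenyl or pyridine ring, or a pyridine ring bearing an amine or a carboxylic acid, would fall with these pyridines or nearer compound 1.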